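The source may report more compounds than this note shows. Statements on the series, on what has been measured and on what is new or still open speak of the compounds shown alone.

Of the compounds shown here, two have so far been measured in a functional assay on Ehrlich cells (Mus musculus) for cytotoxicity, read by trypan blue exclusion, with a stated time of 2 h, tested at 1 ug/mL; a lower number here means a stronger effect, a higher number a weaker effect of the compound at the concentration tested. Compound 1 `CCOc1ccc(NCc2nc3cc(OC)ccc3[n+]([O-])c2-c2ccccc2)cc1` gives 100% in this assay. Compound 2 `COc1ccc2c(c1)[n+]([O-])c(C(=O)N=[N+]=[N-])c(C)[n+]2[O-]` gives 94.5% in this assay. Compound 2 stands at the lower of the two numbers, yet its gap to compound 1 is within the scatter, so nothing separates the two: each shows only a weak effect at the concentration tested.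

Within the data shown here, compound 3 `COc1ccc2c(c1)[n+]([O-])c(NC(=O)OC(C)C)c(C)[n+]2[O-]` keeps the core of compound 2 and differs from it in one place: a group of 7 heavy atoms (4 carbon, 1 nitrogen, 2 oxygen; no ring) in place of a group of 5 heavy atoms (1 carbon, 3 nitrogen, 1 oxygen; no ring), on an aromatic carbon No pair of measured compounds shows what such a change does in this assay. With both measured numbers sitting close to the top of the scale, there is little room left for a rise, and the data give no ground for a fall. The expected step is none beyond the scatter, namely a number 0.5 percentage points higher from compound 2 to compound 3 (within the scatter). Compound 3 is therefore estimated to give 95% in this assay, with a range running from 80% to 100%.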

Compound 3, a percentage reported as activity, at one concentration (the size of the read-out at that concentration, not a potency): 94.8%
For compound 3 the middle estimate is 0.2 percentage points above the measured one; the measured number falls inside the stated range.
By their numbers in this assay, from the lowest: compounds 2, 3 and 1 (each within the scatter of the next).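

On the aromatic carbon next to the ring nitrogen, putting (isopropoxycarbonyl)amino in place of the group carried by compound 2 gives a number 0.3 percentage points higher from compound 2 to compound 3 (within the scatter) in this assay, so this first comparison at this position cannot tell the two compounds apart. The two groups differ in size, in their count of double bonds outside aromatic rings and in their hydrogen-bond donors and acceptors, yet at this single concentration that difference in structure does not appear as any difference beyond the scatter, and both compounds show only a weak effect. No measurement available here offers an explanation for this result.

With both numbers close to the top of the scale, a single pair leaves open whether any group on this carbon can bring a clearly stronger effect, for example a plain amine, a carboxylic acid or a longer chain in place of the isopropyl part of the carbamate. From the compounds shown here alone, it also remains open whether these two compounds would separate at a concentration other than the one tested, since a reading at one concentration says nothing about potency.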